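Bromo in Place of Chloro: From Compound 3 to Compound 4

The compounds below may be only part of what the source reports. "The series", "measured", "known", "first", "only" and "open" are said of these compounds alone.

Of the compounds shown here, three have been tested in a functional assay on MCF7 cells (Homo sapiens) for cytotoxicity, read by MTT assay, with a stated time of 72 h; a lower number here means a stronger inhibitor, a higher number a weaker inhibitor. Compound 1 `O=C(CSC(=S)N[C@H]1CCOC1=O)Nc1ccc(O)cc1` gives only > 128000 nM, which is a limit of the assay and not a number (the limit of > 128000 nM in this assay, at which 1 of the 3 values shown sits). Compound 2 `CCCCCCCCCCCCCCSC(=S)N[C@H]1CCOC1=O` gives 30500 nM. Compound 3 `O=C(CCl)Nc1ccc(C(=O)/C=C/c2ccc(Cl)cc2)cc1` gives 4100 nM, the lowest of the two numbers obtained, and its gap to compound 2 lies beyond the usual scatter of repeated measurements.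

Compound 4 `O=C(CCl)Nc1ccc(C(=O)/C=C/c2ccc(Br)cc2)cc1` has not yet been measured. It differs from compound 3 in a single change, (bromo in place of chloro on an aromatic carbon), in words bromo in place of chloro on an aromatic carbon. For the measured compounds named here, no measured pair here shows this same exchange, so there is no direct precedent to lean on. One halogen traded for another at the same position is expected to move the number little, if at all, so the step is expected to stay within the scatter. The estimate for compound 4 is 4000 nM, with a range from 1500 nM to 10000 nM. This expected value amounts to a step of a 1.0-fold lower number from compound 3 to compound 4 (0.01 log units; within the scatter).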

Compound 4, half-maximal inhibitory concentration: 4640 nM
The estimate for compound 4 lay 1.2-fold (0.06 log units) below the measured number; the measured number falls inside the stated range.
By their numbers in this assay, from the lowest: compounds 3 and 4 (each within the scatter of the next); then compound 2. At a limit, above all of these: compound 1.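

In this assay, for the compounds shown here, a step of a 1.1-fold higher number from compound 3 to compound 4 (0.05 log units; within the scatter) gives the first pair of measured compounds that differ in only one place. Going by these compounds alone, on this aromatic carbon, para to a large group, 4-chlorophenyl and 4-bromophenyl cannot be told apart by this read-out, something the earlier compounds, which differ from one another in more than one place, could not show. Nothing shown here bears on why the two halogens read alike.

The compounds shown leave open whether a smaller or larger halogen, fluoro or iodo, would also read alike at this place. They also leave open whether a quite different group there, such as an amine, a carboxylic acid or a methoxy group, would move the number beyond the scatter.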